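The source may report more compounds than this note shows. Statements on the series, on what has been measured and on what is new or still open speak of the compounds shown alone.

The measured compounds and their values in a functional assay (Oryctolagus cuniculus) for inhibition of platelet-activating factor receptor (Cavia porcellus); a lower number here means a stronger inhibitor, a higher number a weaker inhibitor:
compound 1, `CCCCCCCCCCCCCCCCCC(=O)OCC1CN(C(=O)c2cc(OC)c(OC)c(OC)c2)CCN1C(=O)c1cc(OC)c(OC)c(OC)c1`, gives 45000 nM;
compound 2, `COc1cc(N2CCN(c3cc(OC)c(OC)c(OC)c3)CC2)cc(OC)c1OC`, gives 12500 nM;
compound 3, `COc1cc(C(=O)N2CCN(C(=O)c3cc(OC)c(OC)c(OC)c3)C(COC(=O)NC(C)(C)C)C2)cc(OC)c1OC`, gives 130 nM.

Of these three, compound 3 has the lowest number in this assay and is the strongest inhibitor of the set: the gap to compound 2, and the still wider gap to compound 1, both lie well beyond the usual scatter of repeated measurements. No pair of these compounds differs in only one place, so no single step between them can be read off.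

Compound 4, `CCC(C)CNC(=O)OCC1CN(C(=O)c2cc(OC)c(OC)c(OC)c2)CCN1C(=O)c1cc(OC)c(OC)c(OC)c1`, has not yet been measured. It shares the core of compound 3 and differs in one respect only: 2-methylbutyl in place of tert-butyl on an amide-type nitrogen. Both groups are plain alkyl chains; the change adds no hydrogen-bond donor or acceptor and no charge. No measured step of this kind exists among these compounds, so nothing in the numbers points to a clear direction. The expectation is that the step from compound 3 to compound 4 in this assay will be small, a 1.2-fold higher number from compound 3 to compound 4 (0.06 log units; within the scatter), and will most likely stay within the scatter. Compound 4 is expected to give 150 nM in this assay, with a likely range from 50 nM to 500 nM.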

Compound 4, half-maximal inhibitory concentration: 470 nM
For compound 4 the middle estimate is 3.1-fold (0.50 log units) below the measured one; the measured number falls inside the stated range.
By their numbers in this assay, from the lowest: compound 3; then compound 4; then compound 2; then compound 1.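

In this assay, among these compounds, replacing tert-butyl with 2-methylbutyl on an amide-type nitrogen gives a 3.6-fold higher number from compound 3 to compound 4 (0.56 log units; beyond the scatter), the first single change that can be read in this set, and it shows that this position is not indifferent to which plain alkyl group it carries. The two groups have the same count of hydrogen-bond donors and acceptors and no net charge, and they differ only in their carbon framework, so a change confined to alkyl carbon is enough to move the number modestly beyond the scatter. Nothing in the data shown explains why the number rises with this change.

On these data alone, with only this one replacement to go on, it remains open how a straight butyl chain, a cyclohexyl ring or a benzyl group on the same nitrogen would compare with compound 3, which gives 130 nM. Compound 1 and compound 2 each differ from the others in more than one place, so steps involving them cannot be read, and the contribution of the rest of the molecule stays unresolved.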